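Replacing a hydroxylated chain with an aminated one on a shared core

This account rests on a few compounds, and the source may have more. Where it says the series, first, only, none or still open, it means among the compounds named here.

For the measured compounds named here, compound 2 `CCC(O)CSc1nc(NCc2ccc(-c3ccccn3)cc2)c2[nH]nc(C(C)C)c2n1` gives 273 nM in a functional assay on HT cells (Homo sapiens) for antiproliferative activity, read by fluorescence, with a stated time of 72 h (a higher number here means a weaker inhibitor of growth, a lower number a stronger inhibitor of growth), the second highest of the three numbers known. Compound 1 `CC(C)c1n[nH]c2c(NCc3ccc(-c4ccccn4)cc3)nc(SCCNC(=N)N)nc12` gives 390 nM, and compound 3 `CC(C)c1n[nH]c2c(NCc3ccc(-c4ccccn4)cc3)nc(SC[C@H](O)CN)nc12` gives 63 nM. Compound 4 `CNCCSc1nc(NCc2ccc(-c3ccccn3)cc2)c2[nH]nc(C(C)C)c2n1` carries (methylamino)methyl in place of 1-hydroxypropyl on a saturated chain carbon bound to a sulfur. Going by the values given here, two measured steps bear on this: a 1.4-fold lower number from compound 1 to compound 2 (0.15 log units; within the scatter), and a 4.3-fold lower number from compound 2 to compound 3 (0.64 log units; beyond the scatter), where a chain bearing a nitrogen replaced one without. Compound 4 likewise brings a nitrogen into the chain, so a modest step toward a lower number is expected, a 2.3-fold lower number from compound 2 to compound 4 (0.36 log units; beyond the scatter). Compound 4 is therefore estimated at 120 nM, with a range from 50 nM to 300 nM.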

Compound 4, concentration for 50% growth inhibition: 56 nM
Compound 4: middle estimate off by 2.1-fold (0.33 log units), on the high side; the measured number falls inside the stated range.
By their numbers in this assay, from the lowest: compounds 4 and 3 (each within the scatter of the next); then compounds 2 and 1 (each within the scatter of the next).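

In this assay, (methylamino)methyl in place of 1-hydroxypropyl gives a 4.9-fold lower number from compound 2 to compound 4 (0.69 log units; beyond the scatter), so a nitrogen-bearing chain without a hydroxyl reaches the lowest numbers seen here. Against the 2-amino-1-hydroxyethyl of compound 3, the step reads a 1.1-fold lower number from compound 3 to compound 4 (0.05 log units; within the scatter), within the scatter, so the hydroxyl is not needed to hold this level. On the amine nitrogen, one carbon atom in place of the larger group gives a 7.0-fold lower number from compound 1 to compound 4 (0.84 log units; beyond the scatter). Nothing available explains why these numbers differ. Going by these compounds, whether a dimethylamino group or a longer chain carrying the amine would keep such numbers stays open.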